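Aryl swap on the amide-type nitrogen of compound 3

This account rests on a few compounds, and the source may have more. Where it says the series, first, only, none or still open, it means among the compounds named here.

Measured so far:
compound 1 `Nc1nc(N2CCN(C(=O)COc3ccc(Cl)cc3)CC2)c2ccsc2n1` gives 330 nM in a functional assay on cells (Lymphocyte); on this read-out lower numbers stand for stronger inhibition and higher numbers for weaker inhibition;
compound 2 `Cc1cccc(OCC(=O)N2CCN(c3nc(N)nc4sccc34)CC2)c1` gives 210 nM;
compound 3 `Cc1cccc(NC(=O)N2CCN(c3nc(N)nc4sccc34)CC2)c1` gives 930 nM.

Compound 3 carries the highest number of the three, meaning the weakest inhibition in this set: its number sits a 2.8-fold higher number from compound 1 to compound 3 (0.45 log units; beyond the scatter) and a 4.4-fold higher number from compound 2 to compound 3 (0.65 log units; beyond the scatter), both beyond the scatter. The two compounds that differ from it at the carbonyl carbon lie close to each other, since the step of a 1.6-fold lower number from compound 1 to compound 2 (0.20 log units; within the scatter) is within the scatter.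

Compound 4 `Nc1nc(N2CCN(C(=O)Nc3ccc(Cl)cc3)CC2)c2ccsc2n1` is the next compound and has not been measured. It differs from compound 3 only in the aryl group: 4-chlorophenyl in place of 3-methylphenyl on an amide-type nitrogen

Among the measured compounds shown here, the only measured step that bears on this change is the one between compound 1 and compound 2, where the same two aryl groups are exchanged in the other direction, on an oxygen on a saturated carbon: a 1.6-fold lower number from compound 1 to compound 2 (0.20 log units; within the scatter), within the scatter. Read backwards, that step suggests a slightly higher number for compound 4 than for compound 3, but a step of that size is not distinguishable from repeat measurement. The steps into compound 3 concern the linker, not the aryl group, and do not speak to this change.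

Expectation for compound 4: a number close to that of compound 3, estimated as a 1.4-fold higher number from compound 3 to compound 4 (0.15 log units; within the scatter), giving 1300 nM with a range of 500 nM to 3500 nM.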

Compound 4, half-maximal inhibitory concentration: 6700 nM
For compound 4 the middle estimate is 5.2-fold (0.71 log units) below the measured one; the whole stated range lies below it.
By their numbers in this assay, from the lowest: compounds 2 and 1 (each within the scatter of the next); then compound 3; then compound 4.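

In this assay the aryl exchange on the amide-type nitrogen is far from silent: a 7.2-fold higher number from compound 3 to compound 4 (0.86 log units; beyond the scatter), whereas the reverse exchange on an oxygen on a saturated carbon gave only a 1.6-fold lower number from compound 1 to compound 2 (0.20 log units; within the scatter), so among these compounds the outcome of exchanging these two aryl groups differs with the place of attachment. The carbonyl substituent also matters more when 4-chlorophenyl is on the nitrogen: (4-chlorophenyl)amino in place of (4-chlorophenoxy)methyl gives a 20-fold higher number from compound 1 to compound 4 (1.31 log units; beyond the scatter), and in place of (3-methylphenoxy)methyl it gives a 32-fold higher number from compound 2 to compound 4 (1.50 log units; beyond the scatter), both larger than the earlier 4.4-fold higher number from compound 2 to compound 3 (0.65 log units; beyond the scatter) for (3-methylphenyl)amino. Nothing shown accounts for the different behaviour of the two aryl groups at the two attachments.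

The compounds shown leave open whether the high number of compound 4 follows from the chlorine itself or from its place on the ring, since the chlorine and the methyl also sit at different ring positions; 3-chlorophenyl and 4-methylphenyl on the same nitrogen would separate the two. Also open, from the compounds shown here alone, is how an unsubstituted phenyl or a benzyl group on that nitrogen would compare with compound 3 and compound 4.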